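A few compounds are considered here, and "the series" means these few. Any claim that something is new, unique, unknown or untested is made for them only; others in the source may bear on it.

Compound 1 `COc1cc2nc(N3CCN(C(=O)c4ccc(C(F)(F)F)cc4)CC3)nc(N)c2cc1OC` and compound 2 `COc1cc2nc(N3CCN(S(=O)(=O)c4ccc([N+](=O)[O-])cc4)CC3)nc(N)c2cc1OC` were measured in a functional assay on PC-3 cells (Homo sapiens) for inhibition; a higher number here means a weaker inhibitor, a lower number a stronger inhibitor. For compound 1 this assay gave only a limit, > 100000 nM. Compound 2 gave 36000 nM in this assay, the only number among the two results shown. The result for compound 1 is the limit of > 100000 nM in this assay, at which 1 of the 2 values shown sits.

Compound 3 `COc1cc2nc(N3CCN(S(=O)(=O)c4ccc(N)cc4N)CC3)nc(N)c2cc1OC` has not yet been measured. It differs from compound 2 by one change: 2,4-diaminophenyl in place of 4-nitrophenyl on a sulfonyl sulfur. For the measured compounds named here, no measured step like this exists here, so the expectation for compound 3 rests on compound 2 alone, and the step of a 1.1-fold higher number from compound 2 to compound 3 (0.05 log units; within the scatter) is expected to stay within the scatter. For compound 3 the estimate in this assay is 40000 nM, between 10000 nM and 150000 nM.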

Compound 3, half-maximal inhibitory concentration: 67000 nM
Compound 3: middle estimate off by 1.7-fold (0.22 log units), on the low side; low and high end bracket the measured number.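

In this assay, 2,4-diaminophenyl in place of 4-nitrophenyl on a sulfonyl sulfur gives a 1.9-fold higher number from compound 2 to compound 3 (0.27 log units; within the scatter), so the two groups cannot be told apart at this position, although one carries hydrogen-bond donors and the other none. Compound 1 remains the only result that is a limit rather than a number: the limit of > 100000 nM in this assay, at which 1 of the 3 values shown sits.

On these data alone, whether an unsubstituted phenyl, a carboxylic acid on the ring or a methyl directly on the sulfonyl sulfur would read differently stays open. The compounds shown also do not separate the loss of the nitro group from the gain of the two amino groups.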